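The compounds below may be only part of what the source reports. "The series", "measured", "known", "first", "only" and "open" are said of these compounds alone.

Measured so far in a functional assay (aorta) with Rattus norvegicus as the target; on this read-out lower numbers stand for lower potency and higher numbers for higher potency (the scale is a negative logarithm):
compound 1 `CC1(C)C=C(n2ccccc2=O)c2cc(C(=O)c3ccc([N+](=O)[O-])cc3)ccc2O1` gives 6.2
compound 2 `CC1(C)C=C(n2ccccc2=O)c2cc(C(=O)c3ccccc3F)ccc2O1` gives 7.08

Compound 2 holds the higher of the two numbers, the step of a number 0.88 log units higher from compound 1 to compound 2 (beyond the scatter) lying beyond the scatter. Compound 3 `CC1(C)C=C(n2ccccc2=O)c2cc(Br)ccc2O1` differs from compound 2 by bromo in place of (2-fluorophenyl)carbonyl on an aromatic carbon. Going by the values given here, the one measured step compares two groups on the carbonyl carbon and does not bear on removing the whole (2-fluorophenyl)carbonyl; no measured step covers this change. The expectation therefore rests on the change alone: a drop in this assay with wide uncertainty, the step of a number 1.28 log units lower from compound 2 to compound 3 (beyond the scatter) being expected. Compound 3 is estimated at 5.8, between 5 and 6.8.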

Compound 3, logarithm of the reciprocal of the active concentration, log(1/C): 7.84
For compound 3 the middle estimate is 2.04 log units below the measured one, outside the stated range (above it).
By their numbers in this assay, from the lowest: compound 1; then compound 2; then compound 3.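

Bromo in place of (2-fluorophenyl)carbonyl gives, in this assay, a number 0.76 log units higher from compound 2 to compound 3 (beyond the scatter) and so shows that this aromatic carbon does not need the carbonyl or its aromatic ring for a high number. Going by these compounds alone, the earlier step compared only two groups on the carbonyl carbon, whereas this one shows that a single bromine atom can replace the whole group. Nothing available here accounts for this step.

As far as these compounds go, whether bromo itself matters stays open, since chloro, a nitrile or an amine on the same aromatic carbon would test this. Also open, from the compounds shown here alone, is how a simple acetyl group would compare with either compound.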